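The compounds below may be only part of what the source reports. "The series", "measured", "known", "first", "only" and "open" are said of these compounds alone.

The work here concerns a shared core tested in an assay on HEK293 cells for inhibition of solute carrier family 22 member 12 (Homo sapiens), read by scintillation counting, with a stated time of 12 min; a lower number here means a stronger inhibitor, a higher number a weaker inhibitor. Compound 1 `N#CCCc1ccc2nccc(SC3(C(=O)O)CCC3)c2c1` gives 2760 nM in this assay. Compound 2 `N#Cc1ccc(SC2(C(=O)O)CCC2)c2ccccc12`, built on a different core, gives 926 nM in this assay. Of the two numbers recorded so far, compound 1 stands highest, and its gap to compound 2 lies beyond the scatter of repeated measurements.

Compound 3 `O=C(O)C1(Sc2ccnc3ccc(-c4ccccc4F)cc23)CCC1` is the next compound to be examined. It differs from compound 1 in a single place: 2-fluorophenyl in place of 2-cyanoethyl on an aromatic carbon. Going by the values given here, no pair of measured compounds differs by this exchange alone, so nothing in the present numbers speaks directly to what it will do in this assay; only the fact that compound 1 holds the higher of the two recorded values frames the question.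

The step is expected to go downward, toward a stronger inhibitor, by a 3.1-fold lower number from compound 1 to compound 3 (0.49 log units; beyond the scatter), a moderate gain rather than a large one. For compound 3 the estimate in this assay is 900 nM, with a range from 250 nM to 3000 nM.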

Compound 3, half-maximal inhibitory concentration: 333 nM
Compound 3: middle estimate off by 2.7-fold (0.43 log units), on the high side; measured number inside the range.
By their numbers in this assay, from the lowest: compound 3; then compound 2; then compound 1.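

In this assay, placing 2-fluorophenyl instead of 2-cyanoethyl on this aromatic carbon, meta to a fused ring and para to a fused ring, gives an 8.3-fold lower number from compound 1 to compound 3 (0.92 log units; beyond the scatter), a step beyond the scatter. Going by these compounds alone, this is the first direct reading at this position, and it shows that the shared core can carry a larger substituent with an aromatic ring of carbon only while losing the nitrile of the chain and its hydrogen-bond acceptor, and still give a lower number. No measurement bears on why the number falls, and this single exchange cannot separate the contributions of the ring, the fluorine and the loss of the chain, so the gain remains an observation about one pair.

The compounds shown leave open whether the fluorine matters at all, since neither an unsubstituted phenyl nor a phenyl carrying chlorine or methoxy at that position appears among them. They also leave open whether the aromatic ring itself is needed, a question that a cyclohexyl group or a longer chain ending in an amine at the same carbon would address.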